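This account rests on a few compounds, and the source may have more. Where it says the series, first, only, none or still open, it means among the compounds named here.

Measured compounds in a functional assay (aorta) with Oryctolagus cuniculus as the target; on this read-out higher numbers stand for weaker binding and lower numbers for tighter binding:
- compound 1, `COc1cc(C(C)=O)ccc1OCCCN1CCC(C(c2ccccc2)c2ccccc2)CC1`, gives 6.31 nM
- compound 2, `COc1cc(C(C)=O)ccc1OCCCN1CCC(C(NC(C)=O)(c2ccc(F)cc2)c2ccc(F)cc2)CC1`, gives 63.1 nM
- compound 3, `COc1cc(OCCCN2CCC(C(c3ccc(F)cc3)c3ccc(F)cc3)CC2)ccc1C(C)=O`, gives 3.16 nM

Compound 3 has the lowest of the three numbers in this assay. Its nearest neighbour is compound 1, whose number is higher by a gap within the scatter, so the two cannot be ordered. Going by the values given here, compound 2 is the furthest away, with a number higher by a gap beyond the scatter; compound 2 carries the acetylamino group on the central carbon, compound 3 does not, and no other pair separates the two changes.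

Compound 4, `COc1ccccc1OCCCN1CCC(C(c2ccc(F)cc2)c2ccc(F)cc2)CC1`, has not yet been measured in this assay. The change from compound 3 is 2-methoxyphenyl in place of 4-acetyl-3-methoxyphenyl on an oxygen on a saturated carbon. The acetyl group present in every measured compound is lost and the methoxy is placed differently on the ring. Among the compounds with values here, no measured pair isolates this change, so its size is not known from the series. A moderate loss of affinity beyond the scatter is expected, a 3.8-fold higher number from compound 3 to compound 4 (0.58 log units; beyond the scatter), given that the acetyl is shared by all measured compounds. Compound 4 is therefore estimated at 12 nM, within 3 nM to 50 nM.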

Compound 4, dissociation constant: 2.51 nM
The estimate for compound 4 lay 4.8-fold (0.68 log units) above the measured number; the measured number lies below the stated range.
By their numbers in this assay, from the lowest: compounds 4, 3 and 1 (each within the scatter of the next, the first and the last beyond it); then compound 2.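

In this assay, 2-methoxyphenyl in place of 4-acetyl-3-methoxyphenyl on the oxygen gives a 1.3-fold lower number from compound 3 to compound 4 (0.10 log units; within the scatter), so the two compounds cannot be ordered and the acetyl group is not needed for a number in this range when the two fluorinated aryl groups are kept. Going by these compounds alone, until this result every measured compound carried the acetyl group, which left its contribution at this position unknown; the series now holds one compound without it, and that compound stays level with its partner. The step joins two changes in one, the loss of the acetyl group and a different placing of the methoxy, and nothing at hand bears on why the number holds across them.

Going by these compounds, how far these two changes cancel or simply contribute little remains open, since a ring carrying only one of them would be needed to separate them. Also open, on these data alone, is whether this tolerance extends to an amine or a carboxylic acid on the aromatic ring, to a longer chain on the oxygen, or to the acetylamino group on the central carbon in the 2-methoxyphenyl compound.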